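The source may hold more compounds than are shown below. What is called first, only, known or untested is meant among the compounds shown, and "the series" means these compounds.

For the measured compounds named here, in a functional assay on HepG2 cells (Homo sapiens) for antiproliferative activity, read by CCK-8 assay, with a stated time of 72 h (on this read-out lower numbers stand for stronger inhibition and higher numbers for weaker inhibition), two compounds have numbers so far. Compound 1 (`O=C(NO)c1ccc(COc2ccccc2)cc1`) gives 29600 nM, while compound 2 (`Nc1ccccc1NC(=O)c1ccc(COc2ccccc2)cc1`) gives 6700 nM, the lowest of the two numbers. Going by the values given here, the only measured step, a 4.4-fold lower number from compound 1 to compound 2 (0.65 log units; beyond the scatter), is modest but beyond the usual scatter, and it puts 2-aminophenyl in place of hydroxy on an amide-type nitrogen.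

Compound 3 (`CC(C)c1ccc(OCc2ccc(C(=O)Nc3ccccc3N)cc2)cc1`) keeps that 2-aminophenyl and differs from compound 2 elsewhere: isopropyl in place of hydrogen on an aromatic carbon. This is isopropyl in place of hydrogen on an aromatic carbon, para to a large group. Among the compounds with values here, the step from compound 1 bears on this change only loosely, since it was made at a different place, and no measured pair shows what a substituent at this position does. It therefore sets only a rough scale, and the data fix no direction. In this assay, no step beyond the scatter is expected. The estimate amounts to a 1.3-fold lower number from compound 2 to compound 3 (0.13 log units; within the scatter), an expected step with wide uncertainty. For compound 3, the expected value is 5000 nM, with an estimated range from 1600 nM to 15000 nM.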

Compound 3, half-maximal inhibitory concentration: > 32000 nM
Compound 3: a limit, no number (the forecaster's own chance of this, stated with the estimate: 5%); middle value at least 6.4-fold (0.80 log units) away from the limit.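

In this assay, the entry for compound 3 is a limit of the assay and not a number: the limit of > 32000 nM in this assay, at which 1 of the 3 values shown sits. Even so, the change has a readable direction, an at least 4.7-fold higher number from compound 2 to compound 3 (0.67 log units; beyond the scatter), so isopropyl in place of hydrogen on an aromatic carbon, para to a large group, weakens inhibition by a step beyond the scatter. The earlier compounds shown here differed only on the amide-type nitrogen and said nothing about this position, which now proves sensitive to a substituent, although the limit leaves the full size of the step unread.

On these data alone, it remains open whether the loss is particular to isopropyl or would follow from other groups at this place, such as methyl, fluorine or methoxy, and whether an amine or a carboxylic acid there would move the number the other way. As far as these compounds go, it also remains open whether isopropyl would have the same effect with the hydroxy of compound 1 on the amide-type nitrogen in place of the 2-aminophenyl of compound 3.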